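The compounds below may be only part of what the source reports. "The series", "measured", "known", "first", "only" and "open" are said of these compounds alone.

The measured compounds:
compound 1, `COc1ccc(OC(=O)Nc2ccc([Se]C#N)cc2)cc1`, giving 41500 nM in a functional assay on HT-29 cells (Homo sapiens) for cytotoxicity, read by MTT assay, with a stated time of 72 h; a lower number here means a stronger inhibitor of growth, a higher number a weaker inhibitor of growth
compound 2, `CCCOC(=O)Nc1ccc([Se]C#N)cc1`, giving 51900 nM in this assay
compound 3, `CCOC(=O)Nc1ccc([Se][Se]c2ccc(NC(=O)OCC)cc2)cc1`, giving 51100 nM in this assay

Compound 2 stands with the highest of the three numbers, but its gap to compound 3 and its gap to compound 1 both fall within the usual scatter of repeated measurements, so on these data the three compounds cannot be told apart in this assay. Among the measured compounds shown here, no pair among them differs in a single place, so no measured step is available to guide an expectation.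

Compound 4, `C=CCOC(=O)Nc1ccc([Se]C#N)cc1`, is the unmeasured compound. It differs from compound 2 by vinyl in place of ethyl on a saturated chain carbon bound to an oxygen next to a carbonyl group. The change is small in count and leaves the rest of the structure untouched. Without a measured pair of this kind, the expectation for compound 4 rests on compound 2 and the spread of the three values around it. The step from compound 2 to compound 4 is expected to be a 1.0-fold lower number from compound 2 to compound 4 (0.02 log units; within the scatter), that is, no movement beyond the scatter in either direction. Compound 4 is therefore estimated at 50000 nM in this assay, with a range from 25000 nM to 100000 nM.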

Compound 4, concentration for total growth inhibition: 48600 nM
Beside the measured number, compound 4's estimate is 1.0-fold (0.01 log units) above it; low and high end bracket the measured number.
By their numbers in this assay, from the lowest: compounds 1, 4, 3 and 2 (each within the scatter of the next).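

In this assay, the exchange of propyl for allyl gives a 1.1-fold lower number from compound 2 to compound 4 (0.03 log units; within the scatter), a step that lies within the scatter. This is the first pair among the compounds shown that differs in one place, and it shows that, on a saturated chain carbon bound to an oxygen next to a carbonyl group, vinyl can stand in place of ethyl with no change that can be told from the scatter, even though it brings in a double bond outside aromatic rings. Nothing is available here that would explain this result.

The compounds shown leave open whether a longer chain, an amine or a carboxylic acid at this place would move the number beyond the scatter, since one pair of two-carbon groups says nothing about groups of other kinds. Among the compounds shown here, they also leave open how far this reading carries to other compounds, as compound 1 and compound 3 each differ from compound 4 in more than one place and offer no further step to set beside this one.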